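This account rests on a few compounds, and the source may have more. Where it says the series, first, only, none or still open, it means among the compounds named here.

Compound 2 `CC(C)=CCC/C(C)=C/CC/C(C)=C/C(=O)NC(=N)NC(=O)C=C(C)C` shares its core with compound 1 `CC(C)=CCC/C(C)=C/CC/C(C)=C/C(=O)NC(=N)N` and differs from it by carrying (2-methylprop-1-en-1-yl)carbonyl in place of hydrogen on an amine nitrogen. In a functional assay on SK-MEL-28 cells (Homo sapiens) for inhibition, read by MTT assay, with a stated time of 72 h (on this read-out higher numbers stand for weaker inhibition of growth and lower numbers for stronger inhibition of growth), compound 2 gives 24200 nM, the second highest of the three numbers; compound 1 gives 20100 nM, and the two lie a 1.2-fold higher number from compound 1 to compound 2 (0.08 log units; within the scatter) apart, within the scatter. Compound 3 `CC(C)=CCC/C(C)=C/C(=O)NC(=N)NC(=O)C=C(C)C` gives 53400 nM, and the step of a 2.2-fold higher number from compound 2 to compound 3 (0.34 log units; beyond the scatter) is the one that bears on the new change. Compound 4 `CC(C)=CCC/C(C)=C/CC/C(C)=C/C(=O)NC(=N)NC(=O)/C=C(\C)CC/C=C(\C)CCC=C(C)C` differs from compound 2 by 3,7-dimethylocta-2,6-dien-1-yl in place of hydrogen on a saturated chain carbon bound to a double-bonded chain carbon. Since removing a chain on that carbon produced a 2.2-fold higher number from compound 2 to compound 3 (0.34 log units; beyond the scatter), adding a longer chain there is expected to move the number modestly the other way. Compound 4 is therefore expected at 13000 nM, ranging from 5500 nM to 30000 nM, meaning a 1.9-fold lower number from compound 2 to compound 4 (0.27 log units; within the scatter).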

Compound 4, concentration for 50% growth inhibition: 42700 nM
Beside the measured number, compound 4's estimate is 3.3-fold (0.52 log units) below it; measured number outside the range, above it.
By their numbers in this assay, from the lowest: compounds 1, 2, 4 and 3 (each within the scatter of the next, the first and the last beyond it).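

In this assay, placing 3,7-dimethylocta-2,6-dien-1-yl on a saturated chain carbon bound to a double-bonded chain carbon gives a 1.8-fold higher number from compound 2 to compound 4 (0.25 log units; within the scatter), so this long chain is tolerated, with the two numbers staying within the scatter. The earlier step of a 2.2-fold higher number from compound 2 to compound 3 (0.34 log units; beyond the scatter), the loss of 3-methylbut-2-en-1-yl, lay beyond the scatter, and adding this chain did not mirror it. No measurement shown explains this result. The compounds shown leave open whether an amine or a carboxylic acid at this place would keep the number within the scatter of compound 2.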